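The source may hold more compounds than are shown below. What is called first, only, known or untested is meant among the compounds shown, and "the series" means these compounds.

Two close relatives sharing one core have been tested in an assay on isolated protein for inhibition of thyroid hormone receptor alpha (Homo sapiens), read by fluorescence polarization; on this read-out higher numbers stand for weaker inhibition and lower numbers for stronger inhibition. Compound 1, `CN(Cc1ccccc1)C(=O)CNC(=O)c1ccc(S(C)(=O)=O)c([N+](=O)[O-])c1`, sits at the edge of what the measurement can report. In this assay compound 1 gives > 60000 nM, which is a limit rather than a number. Compound 2, `CC(C)N(C(=O)CNC(=O)c1ccc(S(C)(=O)=O)c([N+](=O)[O-])c1)C(C)C`, also stops at that edge. In this assay compound 2 gives > 60000 nM, again a limit and not a number. Both therefore rest at the limit of > 60000 nM in this assay, at which 2 of the 2 values shown sit. Among the compounds with values here, the single step joining them, a step that the two limits leave unreadable from compound 1 to compound 2, cannot be read because both of its ends sit at the limit of > 60000 nM in this assay, at which 2 of the 2 values shown sit, so it offers no size to carry forward. Compound 3, `CS(=O)(=O)c1ccc(C(=O)NCC(=O)N2CCCCC2)cc1[N+](=O)[O-]`, is not yet measured and differs from compound 2 by piperidin-1-yl in place of diisopropylamino on a carbonyl carbon. With no readable step to guide the direction, compound 3 is expected to stay near the same limit, at an estimated 80000 nM in this assay, between 30000 nM and 250000 nM. The expected step for compound 3 is a step that the limit leaves unreadable from compound 2 to compound 3, nothing beyond the scatter.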

Compound 3, half-maximal inhibitory concentration: 44000 nM
Compound 3: the middle estimate sits 1.8-fold (0.26 log units) above what was measured; measured number inside the range.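

In this assay, compound 3 gives 44000 nM, a real number, so a change on this carbonyl carbon can now yield a reading. Compound 1 and compound 2 stay at a limit of the assay: the limit of > 60000 nM in this assay, at which 2 of the 3 values shown sit. Piperidin-1-yl in place of diisopropylamino gives an at least 1.3-fold lower number from compound 2 to compound 3 (0.13 log units; that floor lies within the scatter), and piperidin-1-yl in place of benzyl(methyl)amino gives an at least 1.3-fold lower number from compound 1 to compound 3 (0.13 log units; that floor lies within the scatter). Each of these is only a floor, so the true size of either step could be larger, but what is printed does not by itself separate compound 3 from the other two beyond the scatter.

As far as these compounds go, it remains open whether other amines on this carbonyl carbon, such as pyrrolidine or morpholine, would give a lower number than compound 3. From the compounds shown here alone, it also remains open whether a carboxylic acid in place of the nitro group on the shared core would change the reading.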